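The compounds below may be only part of what the source reports. "The series", "measured", "known", "first", "only" and "open" are said of these compounds alone.

Measured compounds:
compound 1 `CCCc1ccc(N2C(=O)NC3(CSC4=C3C(=O)c3ncccc3C4=O)C2=O)cc1`, 5 nM
compound 2 `COc1ccc(N2C(=O)NC3(CSC4=C3C(=O)c3ncccc3C4=O)C2=O)cc1`, 1 nM
compound 3 `CCc1ccc(N2C(=O)NC3(CSC4=C3C(=O)c3ncccc3C4=O)C2=O)cc1`, 5 nM

These values come from a functional assay on HeLa cells (Homo sapiens) for antiproliferative activity, read by MTT assay, with a stated time of 96 h; a lower number here means a stronger inhibitor, a higher number a weaker inhibitor. Among the three, compound 2 stands lowest: a 5.0-fold lower number from compound 1 to compound 2 (0.70 log units; beyond the scatter) and a 5.0-fold higher number from compound 2 to compound 3 (0.70 log units; beyond the scatter) are both beyond the scatter, whereas no change at the digits printed from compound 1 to compound 3 (within the scatter) leaves propyl and ethyl within the scatter of each other. Compound 4 `Cc1ccc(N2C(=O)NC3(CSC4=C3C(=O)c3ncccc3C4=O)C2=O)cc1` differs from compound 2 in one place: methyl in place of methoxy on an aromatic carbon. The step that bears most directly on this is a 5.0-fold higher number from compound 2 to compound 3 (0.70 log units; beyond the scatter), where ethyl took the place of methoxy, and no change at the digits printed from compound 1 to compound 3 (within the scatter) shows that the length of such a chain left the value unmoved. For compound 4 a step of similar size in the same direction is therefore expected: a 4.0-fold higher number from compound 2 to compound 4 (0.60 log units; beyond the scatter). Compound 4 is estimated at 4 nM, with a range from 2 nM to 10 nM.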

Compound 4, half-maximal inhibitory concentration: 2 nM
Estimate against measurement, compound 4: 2.0-fold (0.30 log units) above; the range from low to high includes it.
By their numbers in this assay, from the lowest: compounds 2 and 4 (each within the scatter of the next); then compounds 1 and 3 (each within the scatter of the next).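

Replacing 4-methoxyphenyl with 4-methylphenyl stays within the scatter (a 2.0-fold higher number from compound 2 to compound 4 (0.30 log units; within the scatter)), so at this position the oxygen of methoxy is not required for a value this low, which the ethyl and propyl compounds could not show. The chain's length also proves to matter once it is as short as methyl (a 2.5-fold lower number from compound 3 to compound 4 (0.40 log units; beyond the scatter); a 2.5-fold lower number from compound 1 to compound 4 (0.40 log units; beyond the scatter)), although ethyl and propyl share one value. Nothing measured here explains these steps. Going by these compounds, whether an amine or a carboxylic acid at this position would give a similar value remains open.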